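Amide nitrogen substituent in the methylsulfonyl series

The compounds below may be only part of what the source reports. "The series", "measured", "known", "first", "only" and "open" are said of these compounds alone.

Working notes on two compounds sharing the core of compound 2 and one related reference. Compound 1 `CC[C@H](NC(=O)COc1ccc2[nH]c(=O)c(-c3nccs3)c(CCc3ccccc3)c2c1)c1ccccc1` carries a thiazolyl group on the core and a branched benzylic group on the amide nitrogen; in an assay on CHO cells for displacement of a labelled ligand from adenosine receptor A2b (Homo sapiens), read by scintillation counting, with a stated time of 60 min (on this read-out higher numbers stand for weaker inhibition and lower numbers for stronger inhibition), compound 1 gives 20 nM. Compound 2 `CS(=O)(=O)c1c(CCc2ccccc2)c2cc(OCC(=O)NCC3CC3)ccc2[nH]c1=O` carries a methylsulfonyl group instead, with cyclopropylmethyl on the amide nitrogen. In this assay, among the measured compounds shown here, compound 2 reaches only the limit of the assay, > 10000 nM, so no number is known for it; compound 2 is the one value that sits at the limit of > 10000 nM in this assay, at which 1 of the 2 values shown sits. For the measured compounds named here, no single-change step between measured compounds is available, so the size of the change to compound 3 can only be expected, not read off.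

Compound 3 `CS(=O)(=O)c1c(CCc2ccccc2)c2cc(OCC(=O)Nc3ccccc3)ccc2[nH]c1=O` differs from compound 2 in one place: phenyl in place of cyclopropylmethyl on an amide-type nitrogen. Because compound 2 stands at the limit of > 10000 nM in this assay, at which 1 of the 2 values shown sits, any reading for compound 3 that is a number would mean a move toward stronger inhibition. The expectation is a modest gain, with a fair chance that compound 3 also returns only a limit. The step expected from compound 2 to compound 3 is an at least 1.2-fold lower number from compound 2 to compound 3 (0.09 log units; that floor lies within the scatter). Compound 3 is estimated at 8000 nM, in the range 1500 nM to 30000 nM.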

Compound 3, inhibition constant: > 10000 nM
Compound 3 gave a limit, no number; the forecaster's own chance of this, stated with the estimate: 50%; middle value at least 1.2-fold (0.09 log units) from the limit.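

Compound 3 gives only a limit in this assay, > 10000 nM. No size can be read for phenyl in place of cyclopropylmethyl on the amide-type nitrogen from compound 2 to compound 3, as both stand at a limit: the limit of > 10000 nM in this assay, at which 2 of the 3 values shown sit.

The compounds shown leave open whether any group on that nitrogen in the methylsulfonyl series gives a number rather than a limit in this assay.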